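Benzoate to dichlorobenzoate on a triterpenoid scaffold

The source may report more compounds than this note shows. Statements on the series, on what has been measured and on what is new or still open speak of the compounds shown alone.

Measured in a functional assay on MDA-MB-231 cells (Homo sapiens) for antiproliferative activity, read by MTT assay, with a stated time of 72 h; on this read-out higher numbers stand for weaker inhibition and lower numbers for stronger inhibition:
- compound 1 `CC1=CCC2C(CC[C@@]2(C)O)C(C)(C)C1CC[C@@H]1[C@@]2(C)CC[C@@H](O)C(C)(C)O[C@@H]2CC[C@]1(C)O`: only a limit of the assay, > 50000 nM
- compound 2 `CC(=O)O[C@H]1CC[C@]2(C)[C@H](CC[C@@](C)(O)[C@H]2CC[C@@H]2C(C)=CC[C@H]3[C@H](CC[C@]3(C)OC(C)=O)C2(C)C)OC1(C)C`: 26200 nM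
- compound 3 `CC1=CC[C@H]2[C@H](CC[C@]2(C)O)C(C)(C)[C@@H]1CC[C@H]1[C@]2(C)CC[C@H](OC(=O)c3ccccc3)C(C)(C)O[C@H]2CC[C@@]1(C)O`: 16100 nM

Compound 3 carries a benzoyl ester on the shared core and gives 16100 nM in this assay. Compound 2 gives 26200 nM, a gap to compound 3 that lies within the usual scatter, so the two cannot be told apart. Compound 1 reaches only a limit of the assay, > 50000 nM, so for it no number is known (the limit of > 50000 nM in this assay, at which 1 of the 3 values shown sits).

Compound 4 `CC1=CC[C@H]2[C@H](CC[C@]2(C)O)C(C)(C)[C@@H]1CC[C@H]1[C@]2(C)CC[C@H](OC(=O)c3ccc(Cl)c(Cl)c3)C(C)(C)O[C@H]2CC[C@@]1(C)O` differs from compound 3 in one place: 3,4-dichlorophenyl in place of phenyl on a carbonyl carbon. Among the compounds with values here, no pair of measured compounds differs in a single place, so no measured step guides this change. The expectation is therefore a small step, in either direction, not clearly beyond the scatter. Compound 4 is estimated to give 10000 nM in this assay, within 3000 nM to 35000 nM, which means an expected step of a 1.6-fold lower number from compound 3 to compound 4 (0.21 log units; within the scatter).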

Compound 4, half-maximal inhibitory concentration: 8100 nM
Estimate against measurement, compound 4: 1.2-fold (0.09 log units) above; low and high end bracket the measured number.
By their numbers in this assay, from the lowest: compounds 4, 3 and 2 (each within the scatter of the next, the first and the last beyond it). At a limit, above all of these: compound 1.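

In this assay, within the data shown here, the first single-place change that can be read at this ester, 3,4-dichlorophenyl in place of phenyl on a carbonyl carbon, comes to a 2.0-fold lower number from compound 3 to compound 4 (0.30 log units; within the scatter), so compound 3 and compound 4 cannot be told apart. Adding two chlorine atoms to the ring of the benzoyl group therefore makes no clear difference to this read-out, in either direction, and the position tolerates the 3,4-dichlorophenyl group without a clear loss or a clear gain. Nothing measured here offers a reason for this result.

As far as these compounds go, whether a different kind of group on this carbonyl carbon could shift the number beyond the scatter stays open. A ring carrying an amine or a carboxylic acid, or a longer chain in place of the ring, would test that.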